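Swapping the Aryl Group on an Inactive Allyl Analogue

A few compounds are considered here, and "the series" means these few. Any claim that something is new, unique, unknown or untested is made for them only; others in the source may bear on it.

Compound 2 `C=CCn1c(=O)/c(=C\c2cc(Br)ccc2F)[nH]c(=O)/c1=C\c1ccccc1OC` has no single number in a functional assay on A549 cells (Homo sapiens) for cytotoxicity, read by CCK-8 assay, with a stated time of 72 h; on this read-out higher numbers stand for weaker inhibition and lower numbers for stronger inhibition; it was reported as "not active" (no number reported). Compound 1 `COc1ccccc1/C=c1/[nH]c(=O)/c(=C\c2cccc(Cl)c2Cl)[nH]c1=O` was likewise reported as "not active" (no number reported) in this assay, whereas compound 3 `COc1ccccc1/C=c1\c(=O)[nH]/c(=C/c2cccc(Cl)c2Cl)c(=O)n1C` gives 200 nM in this assay. Compound 4 `C=CCn1c(=O)/c(=C\c2ccc(C)cc2)[nH]c(=O)/c1=C\c1ccccc1OC` differs from compound 2 by 4-methylphenyl in place of 5-bromo-2-fluorophenyl on a double-bonded chain carbon bound to an aromatic carbon. Among the compounds with values here, no measured pair shows what such a change does in this assay, and compound 2 itself gave no number, so the size and direction of the step cannot be read from any reference. Within the data shown here, the only guide is that starting point, and a shift beyond the usual scatter is not expected. Compound 4 is expected to fall near 20000 nM in this assay, with a range from 3000 nM to 100000 nM, and a report of no number is the likeliest outcome.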

Compound 4, half-maximal inhibitory concentration: "not active" (no number reported)
The entry for compound 4 holds no number; the estimate stays without a comparison.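

In this assay compound 2 and compound 4 both carry no number, and no step can be read between them. No supporting evidence bears on this result. On these data alone, what replacing 5-bromo-2-fluorophenyl with 4-methylphenyl does to the read-out stays open.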